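A few compounds are considered here, and "the series" means these few. Any claim that something is new, unique, unknown or untested is made for them only; others in the source may bear on it.

Among the measured compounds shown here, in a functional assay on Calu-3 cells (Homo sapiens) for cytotoxicity, read by WST assay, with a stated time of 72 h (a higher number here means a weaker inhibitor, a lower number a stronger inhibitor), compound 3 `COc1cccc(-c2cc(-c3cc4ccccc4n3C)no2)c1` gives 17300 nM, the only plain number among the three measured compounds. Compound 1 `Cn1c(-c2cc(-c3cccc(F)c3)on2)cc2ccccc21` stops at > 100000 nM, which is a limit of the assay. Compound 2 `COc1cccc(-c2cc(-c3cc4cc(OC)ccc4[nH]3)no2)c1` likewise stops at > 100000 nM, again a limit. For the measured compounds named here, the single one-place step, an at least 5.7-fold lower number from compound 1 to compound 3 (0.76 log units; beyond the scatter), rests on (the limit of > 100000 nM in this assay, at which 2 of the 3 values shown sit). Compound 4 `COc1cccc(-c2cc(-c3cc4ccccc4[nH]3)no2)c1` arises from compound 3 through (hydrogen in place of methyl on an aromatic nitrogen). Going by the values given here, no measured step covers this change. Among the compounds with values here, compound 2 also carries the ring hydrogen and shows only a limit, yet it differs from compound 3 in more than one place, so its pair with compound 3 offers no isolated step. The expected step is a 2.9-fold higher number from compound 3 to compound 4 (0.46 log units; beyond the scatter), towards a weaker inhibitor, with a fair chance of a limit. Compound 4 is estimated at 50000 nM, between 12000 nM and 150000 nM.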

Compound 4, half-maximal inhibitory concentration: > 100000 nM
Compound 4 gave a limit, no number (the forecaster's own chance of this, stated with the estimate: 45%); at least 2.0-fold (0.30 log units) between middle value and limit.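

In this assay, among the compounds shown here, hydrogen in place of methyl on the aromatic nitrogen gives an at least 5.7-fold higher number from compound 3 to compound 4 (0.76 log units; beyond the scatter) and so provides the first one-place reading at this position. Going by these compounds, of the two groups seen on this nitrogen with otherwise the same core, only methyl gives a plain number, and the true size of the step stays unknown: the limit of > 100000 nM in this assay, at which 3 of the 4 values shown sit. The step between compound 2 and compound 4 cannot be read: both values are limits. Open, on these data alone, is whether an ethyl group, or a longer chain ending in an amine, on this nitrogen would give a plain number in this assay or stay at the limit.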